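A trifluoromethyl swap on the anilide of compound 2

A few compounds are considered here, and "the series" means these few. Any claim that something is new, unique, unknown or untested is made for them only; others in the source may bear on it.

In an ADME assay on HaCaT cells (Homo sapiens) for inhibition (a higher number here means a weaker inhibitor, a lower number a stronger inhibitor), compound 2 `COc1cc(-c2cc(C(=O)O)c3ccccc3n2)ccc1OCC(=O)Nc1cccc(C)c1` stands highest of the two numbers given, at 225000 nM. Compound 1 `COc1cc(-c2cc(C(=O)O)c3ccccc3n2)ccc1OCC(=O)Nc1ccccc1` gives only a limit in this assay, > 300000 nM. Compound 3 `COc1cc(-c2cc(C(=O)O)c3ccccc3n2)ccc1OCC(=O)Nc1ccccc1C(F)(F)F` gives 102000 nM in this assay. The step of an at least 1.3-fold lower number from compound 1 to compound 2 (0.12 log units; that floor lies within the scatter) and the step of an at least 2.9-fold lower number from compound 1 to compound 3 (0.46 log units; beyond the scatter) each start from the limit of compound 1, shown by the limit of > 300000 nM in this assay, at which 1 of the 3 values shown sits, so their size is known only as a floor. Among the compounds with values here, the one fully measured step is a 2.2-fold lower number from compound 2 to compound 3 (0.34 log units; beyond the scatter). Compound 4 `COc1cc(-c2cc(C(=O)O)c3ccccc3n2)ccc1OCC(=O)Nc1ccc(C(F)(F)F)cc1` differs from compound 2 by 4-(trifluoromethyl)phenyl in place of 3-methylphenyl on an amide-type nitrogen. The step from compound 2 to compound 3 bears on this change; both put a (trifluoromethyl)phenyl on the amide-type nitrogen in place of 3-methylphenyl, and that step lowered the number modestly. A step of the same kind and size is therefore expected for compound 4, a 2.0-fold lower number from compound 2 to compound 4 (0.31 log units; beyond the scatter). Compound 4 is thus estimated at 110000 nM in this assay, with a range from 50000 nM to 260000 nM.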

Compound 4, half-maximal inhibitory concentration: 150000 nM
Compound 4: middle estimate off by 1.4-fold (0.13 log units), on the low side, within the range that was stated.
By their numbers in this assay, from the lowest: compounds 3, 4 and 2 (each within the scatter of the next, the first and the last beyond it). At a limit, above all of these: compound 1.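

In this assay, the 4-(trifluoromethyl)phenyl group on the amide-type nitrogen brings no change beyond the scatter relative to 3-methylphenyl, with a 1.5-fold lower number from compound 2 to compound 4 (0.18 log units; within the scatter), whereas the 2-(trifluoromethyl)phenyl group of compound 3 did pass it. The two (trifluoromethyl)phenyl groups themselves cannot be told apart here, with a 1.5-fold higher number from compound 3 to compound 4 (0.17 log units; within the scatter). The remaining step, an at least 2.0-fold lower number from compound 1 to compound 4 (0.30 log units; that floor lies within the scatter), gives only a floor, and the value it starts from is a limit of the assay: the limit of > 300000 nM in this assay, at which 1 of the 4 values shown sits.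

The compounds shown leave open how an amine or a nitrile on this phenyl group would read in this assay, and how a longer chain in place of the phenyl group on the amide-type nitrogen would read. They also leave open whether the small differences among these compounds would hold in any other assay.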